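Swapping dimethylamino for fluoro on a weak lectin binder

The source may hold more compounds than are shown below. What is called first, only, known or untested is meant among the compounds shown, and "the series" means these compounds.

The study concerns three compounds built on one shared core, alongside a fourth that has not yet been tested. Compound 1 `CN(C)C(=O)c1c[nH]c2ccc(N(C)C)cc2c1=O` stands in an assay for binding affinity to C-type lectin domain family 4 member M (Homo sapiens), read by reporter gene assay and NMR (on this read-out lower numbers stand for tighter binding and higher numbers for weaker binding), with no result reported. Compound 3 `CN(C)c1ccc2ncc(C(=O)O)c(O)c2c1` likewise stands in this assay with no result reported. The only figure in hand comes from compound 2 `CCOC(=O)c1c[nH]c2ccc(N(C)C)cc2c1=O`, which in this assay gives 300000 nM, a very weak affinity on this read-out. Compound 1 therefore has no measured footing of its own, and the series as a whole is anchored only by that single weak value.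

Compound 4 `CN(C)C(=O)c1c[nH]c2ccc(F)cc2c1=O` differs from compound 1 in one place: fluoro in place of dimethylamino on an aromatic carbon. Among the measured compounds shown here, no step between two measured compounds is available to calibrate this change, so any expectation rests on the weak showing of compound 2. The author expects the move from compound 1 to compound 4 to produce no shift beyond the usual scatter, with binding remaining faint. Compound 4 is accordingly estimated at 300000 nM in this assay, within a range of 50000 nM to 2000000 nM.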

Compound 4, dissociation constant: 2900000 nM
Beside the measured number, compound 4's estimate is 9.7-fold (0.99 log units) below it; the whole stated range lies below it.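

In this assay compound 4 gives 2900000 nM as its reading, yet no step can be read between compound 1 and compound 4. The compounds shown leave open how fluoro in place of dimethylamino alters binding. No evidence offered here bears on this result.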